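The source may hold more compounds than are shown below. What is called first, only, known or untested is meant among the compounds shown, and "the series" means these compounds.

Working notes on the series. Compound 1 `C[C@]1(O)C[C@@](c2cccc(C(F)(F)F)c2)([C@H](O)c2ccccn2)C1` is the reference, measured in an assay on HEK293 cells for antagonist activity at transient receptor potential cation channel subfamily V member 3 (Homo sapiens), read by FLIPR and calcium flux (on this read-out lower numbers stand for stronger inhibition and higher numbers for weaker inhibition), at 300 nM. Compound 3 `C[C@]1(O)C[C@](c2ccc(C(F)(F)F)cc2)([C@H](O)c2ccccn2)C1` shares its atoms but joins them differently; the difference between the two cores is not broken down here. In this assay compound 3 gives 4790 nM. Compound 2 `O[C@H](c1ccccn1)[C@]1(c2ccc(C(F)(F)F)cc2)C[C@H](O)C1` differs from compound 3 by hydrogen in place of methyl on a saturated ring carbon, and in this assay compound 2 gives 2240 nM, so that the change produced a 2.1-fold lower number from compound 3 to compound 2 (0.33 log units; beyond the scatter). The unmeasured compound 4 `O[C@H](c1ccccn1)[C@]1(c2cccc(C(F)(F)F)c2)C[C@@H](O)C1` differs from compound 1 by hydrogen in place of methyl on a saturated ring carbon, the same change made at the same place on the core of compound 1. On the strength of that one precedent, the step from compound 1 to compound 4 is expected to be a 2.1-fold lower number from compound 1 to compound 4 (0.33 log units; beyond the scatter), a modest gain of the same order as the step seen from compound 3 to compound 2. The estimate for compound 4 in this assay is therefore 140 nM, with a likely range from 60 nM to 350 nM.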

Compound 4, antagonist equilibrium constant: 210 nM
Estimate against measurement, compound 4: 1.5-fold (0.18 log units) below, and the stated range covers the measured number.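

In this assay, hydrogen in place of methyl on a saturated ring carbon of the core of compound 1 gives a 1.4-fold lower number from compound 1 to compound 4 (0.15 log units; within the scatter), so this step alone does not separate the two compounds. Set beside the earlier step, it shows no measurable difference in how the change reads on the two cores: the same change on two cores in this assay, a 2.1-fold lower number (0.33 log units; beyond the scatter) from compound 3 to compound 2 and a 1.4-fold lower number (0.15 log units; within the scatter) from compound 1 to compound 4, 1.5-fold (0.18 log units) apart, within the scatter of two such steps. This supports carrying the change between these two cores, but two pairs establish no rule for the wider series and do not explain the agreement.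

The compounds shown leave open how an ethyl group, a fluorine or an amine on that ring carbon would read in this assay. As far as these compounds go, whether the step holds on a core bearing a nitrile in place of the trifluoromethyl group also remains open.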